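The source may hold more compounds than are shown below. What is called first, only, known or untested is meant among the compounds shown, and "the series" means these compounds.

Measured compounds:
- compound 1, `COc1cc(/C=C/C(=O)c2cccc(-n3cc(-c4ccc(Cl)cc4)[nH]c3=O)c2)ccc1O`, 3400 nM
- compound 2, `COc1cc(/C=C/C(=O)c2cccc(-n3cc(-c4ccccc4)[nH]c3=O)c2)cc(OC)c1OC`, 1510 nM
- compound 3, `COc1cc(/C=C/C(=O)c2cccc(-n3cc(-c4ccccc4)[nH]c3=O)c2)ccc1O`, 2210 nM

All three were tested in a functional assay on COLO 205 cells (Homo sapiens) for inhibition; on this read-out higher numbers stand for weaker inhibition of growth and lower numbers for stronger inhibition of growth. Among them compound 1 gives the highest number, so it is the weakest inhibitor of growth of the three. Its nearest neighbour is compound 3, reached by a 1.5-fold lower number from compound 1 to compound 3 (0.19 log units; within the scatter), a change that lies within the scatter. Compound 2 stands furthest away, a gap beyond the scatter, but it differs from compound 1 in more than one place, so the two values only show where each stands.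

The unmeasured compound 4, `O=C(/C=C/c1cccc(O)c1)c1cccc(-n2cc(-c3ccc(Cl)cc3)[nH]c2=O)c1`, differs from compound 1 by 3-hydroxyphenyl in place of 4-hydroxy-3-methoxyphenyl on a double-bonded chain carbon bound to a double-bonded chain carbon. For the measured compounds named here, none of the measured steps alters this part of the molecule: the only single-point step, from compound 1 to compound 3, concerns the chloro group elsewhere and was within the scatter. What compounds 2 and 3 show is that reshaping the groups on this ring leaves the values in a similar region. The expected step from compound 1 to compound 4 in this assay is therefore a 1.1-fold lower number from compound 1 to compound 4 (0.03 log units; within the scatter), with no direction that can be argued for beyond the scatter. Compound 4 is estimated at 3200 nM, within a range of 1200 nM to 8500 nM.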

Compound 4, concentration for 50% growth inhibition: 2290 nM
The estimate for compound 4 lay 1.4-fold (0.15 log units) above the measured number; measured number inside the range.
By their numbers in this assay, from the lowest: compounds 2, 3, 4 and 1 (each within the scatter of the next, the first and the last beyond it).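

In this assay the only step shown at this position is a 1.5-fold lower number from compound 1 to compound 4 (0.17 log units; within the scatter) and it puts 3-hydroxyphenyl in place of 4-hydroxy-3-methoxyphenyl on a double-bonded chain carbon bound to a double-bonded chain carbon. The group goes from 9 heavy atoms to 7 and from 2 hydrogen-bond acceptors to 1, keeping its 1 hydrogen-bond donor, and this read-out does not tell the two compounds apart. No measurement is at hand that could explain this result.

The two ring groups differ in more than one way, so the compounds shown do not separate what the methoxy group and the hydroxy group each contribute. They also leave open what an amine, a carboxylic acid or a longer chain on this ring would give.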